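The source may hold more compounds than are shown below. What is called first, only, known or untested is meant among the compounds shown, and "the series" means these compounds.

Compound 1: `CC(=O)OCCC(=O)O[C@H](CC=C(C)C)C1=CC(=O)c2c(O)ccc(O)c2C1=O`, 15700 nM.
Compound 2: `CC(C)=CC[C@@H](OC(=O)CC(C)(O)c1ccccc1)C1=CC(=O)c2c(O)ccc(O)c2C1=O`, > 100000 nM.
Compound 3: `CCCC(O)CC(=O)O[C@H](CC=C(C)C)C1=CC(=O)c2c(O)ccc(O)c2C1=O`, > 100000 nM.

Among the compounds with values here, in a functional assay on DU-145 cells (Homo sapiens) for cytotoxicity, read by MTT assay (on this read-out higher numbers stand for weaker inhibition and lower numbers for stronger inhibition), compound 1 gives 15700 nM, the only plain number among the three measured compounds. For compound 2 the assay reports only a limit, > 100000 nM. For compound 3 the result is likewise a limit, > 100000 nM. Both steps away from compound 1 are therefore read only as lower bounds: an at least 6.3-fold higher number from compound 1 to compound 2 (0.80 log units; beyond the scatter), and an at least 6.3-fold higher number from compound 1 to compound 3 (0.80 log units; beyond the scatter). Between compound 2 and compound 3 the step is a step that the two limits leave unreadable from compound 2 to compound 3.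

Compound 4, `CC[C@](C)(O)CC(=O)O[C@H](CC=C(C)C)C1=CC(=O)c2c(O)ccc(O)c2C1=O`, has not been measured. Its difference from compound 1 is 1-hydroxy-1-methylpropyl in place of acetoxymethyl on a saturated chain carbon bound to a carbonyl carbon. The two measured steps bear on it directly: in compound 2 and compound 3 a group carrying a hydroxy, 1-hydroxy-1-phenylethyl and 1-hydroxybutyl, replaced the acetoxymethyl at the same place. Because both of them ended at the limit of > 100000 nM in this assay, at which 2 of the 3 values shown sit, compound 4 is expected to follow the same course, with the step estimated as a 6.4-fold higher number from compound 1 to compound 4 (0.80 log units; beyond the scatter). Compound 4 is therefore estimated at 100000 nM, between 30000 nM and 300000 nM, and the assay may well report only a limit.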

Compound 4, half-maximal inhibitory concentration: 20500 nM
Compound 4: middle estimate off by 4.9-fold (0.69 log units), on the high side; the whole stated range lies above it.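

In this assay, a group carrying a hydroxy at this place does not by itself push the number up to the limit: 1-hydroxy-1-methylpropyl in place of acetoxymethyl on a saturated chain carbon bound to a carbonyl carbon gives a 1.3-fold higher number from compound 1 to compound 4 (0.12 log units; within the scatter), so the two groups stand level here. The outcome therefore depends on which hydroxy-bearing group sits at this place, as the comparisons with 1-hydroxybutyl, an at least 4.8-fold lower number from compound 3 to compound 4 (0.68 log units; beyond the scatter), and with 1-hydroxy-1-phenylethyl, an at least 4.8-fold lower number from compound 2 to compound 4 (0.68 log units; beyond the scatter), both show. These two steps are lower bounds, and the step between compound 2 and compound 3 cannot be read, since each of those compounds gives only a limit: the limit of > 100000 nM in this assay, at which 2 of the 4 values shown sit.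

The compounds shown leave open whether the opposite configuration at the defined stereocentre of 1-hydroxy-1-methylpropyl would keep the level of compound 4. They also leave open how an amine, a carboxylic acid or a longer chain on this saturated chain carbon would read in this assay.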